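This account rests on a few compounds, and the source may have more. Where it says the series, first, only, none or still open, it means among the compounds named here.

Measured compounds:
Compound 1 `COc1ccc(/C=N/NC(=O)Nc2ccc(Oc3ccnc(-c4nncn4CCN(C)C)c3)c(F)c2)c(OC)c1` gives 1570 nM in a functional assay on NCI-H460 cells (Homo sapiens) for cytotoxicity, read by MTT assay, with a stated time of 72 h; on this read-out lower numbers stand for stronger inhibition and higher numbers for weaker inhibition.
Compound 2 `CN(C)CCn1cnnc1-c1cc(Oc2ccc(NC(=O)N/N=C/c3ccccc3O[N+](=O)[O-])cc2F)ccn1` gives 1270 nM in this assay.
Compound 3 `CN(C)CCn1cnnc1-c1cc(Oc2ccc(NC(=O)N/N=C/c3ccc(F)cc3)cc2F)ccn1` gives 1980 nM in this assay.

Compound 3 carries the highest of the three numbers, yet both of its distances lie within the scatter: a 1.3-fold higher number from compound 1 to compound 3 (0.10 log units; within the scatter) and a 1.6-fold higher number from compound 2 to compound 3 (0.19 log units; within the scatter). The three measured compounds differ only in the aryl group on the carbon with a double bond to nitrogen, and every exchange there, including a 1.2-fold lower number from compound 1 to compound 2 (0.09 log units; within the scatter), stayed within the scatter.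

Compound 4 `CN(C)CCn1cnnc1-c1cc(Oc2ccc(NC(=O)N/N=C/c3ccc(F)cc3F)cc2F)ccn1` differs from compound 3 by fluoro in place of hydrogen on an aromatic carbon. Going by the values given here, no measured step adds a fluoro group to this ring, so the closest guidance comes from the three aryl exchanges, all of them small. A change of one fluorine at the same aryl group is therefore expected to produce no step beyond the scatter, and the step from compound 3 to compound 4 is estimated as a 1.1-fold lower number from compound 3 to compound 4 (0.04 log units; within the scatter). Compound 4 is expected to give about 1800 nM in this assay, with a range from 900 nM to 3600 nM.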

Compound 4, half-maximal inhibitory concentration: 1930 nM
For compound 4 the middle estimate is 1.1-fold (0.03 log units) below the measured one, and the stated range covers the measured number.
By their numbers in this assay, from the lowest: compounds 2, 1, 4 and 3 (each within the scatter of the next).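

In this assay, going by these compounds alone, the change from 4-fluorophenyl to 2,4-difluorophenyl, which places a fluoro group ortho to a large group and meta to a fluoro group, stays within the scatter (a 1.0-fold lower number from compound 3 to compound 4 (0.01 log units; within the scatter)), and it is the first measured change at this aryl group that alters a single atom. The new 2,4-difluorophenyl group also stays within the scatter of the 2-(nitrooxy)phenyl group (a 1.5-fold higher number from compound 2 to compound 4 (0.18 log units; within the scatter)) and of the 2,4-dimethoxyphenyl group (a 1.2-fold higher number from compound 1 to compound 4 (0.09 log units; within the scatter)), so this position now shows no step beyond the scatter across four aryl groups. Nothing available explains why these exchanges stay so small.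

The compounds shown leave open whether an amine or a carboxylic acid on this ring would move the number beyond the scatter. On these data alone, a longer chain at the same aromatic carbon remains equally open.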